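Swapping the benzyl aryl group on the sulfur-linked chain

The compounds below may be only part of what the source reports. "The series", "measured", "known", "first", "only" and "open" are said of these compounds alone.

Measured compounds:
compound 1 `Cc1cc(N2CC[C@@H](C)[C@@H](N(C)c3ncnc4[nH]ccc34)C2)n2nc(SCc3ccc(C(F)(F)F)cc3)nc2n1` in a functional assay on BGC-823 cells (Homo sapiens) for inhibition, read by MTT assay, with a stated time of 72 h (a higher number here means a weaker inhibitor, a lower number a stronger inhibitor), gives 23300 nM;
compound 2 `Cc1cc(N2CC[C@@H](C)[C@@H](N(C)c3ncnc4[nH]ccc34)C2)n2nc(SCc3ccc(Cl)cc3)nc2n1` in this assay gives 26300 nM;
compound 3 `Cc1cc(N2CC[C@@H](C)[C@@H](N(C)c3ncnc4[nH]ccc34)C2)n2nc(SCc3ccc(F)c(Cl)c3)nc2n1` in this assay gives 98900 nM.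

Compound 3 gives the highest number of the three: the step of a 4.2-fold higher number from compound 1 to compound 3 (0.63 log units; beyond the scatter) and the step of a 3.8-fold higher number from compound 2 to compound 3 (0.58 log units; beyond the scatter) both lie beyond the scatter, whereas the step of a 1.1-fold higher number from compound 1 to compound 2 (0.05 log units; within the scatter) does not. Compound 4 `COc1ccc(CSc2nc3nc(C)cc(N4CC[C@@H](C)[C@@H](N(C)c5ncnc6[nH]ccc56)C4)n3n2)cc1` differs from compound 3 in one place, (4-methoxyphenyl in place of 3-chloro-4-fluorophenyl on a saturated chain carbon bound to a sulfur). The two steps that bear on this are those leading into compound 3, a 4.2-fold higher number from compound 1 to compound 3 (0.63 log units; beyond the scatter) and a 3.8-fold higher number from compound 2 to compound 3 (0.58 log units; beyond the scatter), each a modest rise in number on going to the 3-chloro-4-fluorophenyl group. Compound 4 goes back to a singly substituted ring at the same place, so a modest drop in number in this assay is expected, towards the region of compound 1 and compound 2, though the 4-methoxyphenyl group itself has not been measured here. The expected step is a 2.5-fold lower number from compound 3 to compound 4 (0.39 log units; beyond the scatter). Compound 4 is therefore estimated at 40000 nM in this assay, within 15000 nM to 120000 nM.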

Compound 4, half-maximal inhibitory concentration: 69900 nM
Estimate against measurement, compound 4: 1.7-fold (0.24 log units) below; measured number inside the range.
By their numbers in this assay, from the lowest: compounds 1 and 2 (each within the scatter of the next); then compounds 4 and 3 (each within the scatter of the next).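

In this assay, the 4-methoxyphenyl group on the saturated chain carbon bound to a sulfur does not fall in with the 4-chlorophenyl and 4-(trifluoromethyl)phenyl groups, as a 2.7-fold higher number from compound 2 to compound 4 (0.42 log units; beyond the scatter) and a 3.0-fold higher number from compound 1 to compound 4 (0.48 log units; beyond the scatter) both show. Instead, a 1.4-fold lower number from compound 3 to compound 4 (0.15 log units; within the scatter) places the singly substituted ring of compound 4 level with the doubly substituted ring of compound 3, so having one substituent rather than two does not by itself separate these compounds, and compound 4 goes against that reading of the earlier results. Nothing measured here accounts for this difference among the singly substituted rings. The compounds shown leave open how an unsubstituted phenyl ring would compare at this position. They also leave open whether a 3-chlorophenyl group would stand with compound 3 or with compound 2.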